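Ester swap on a shared core: predicting cytotoxicity

The source may hold more compounds than are shown below. What is called first, only, known or untested is meant among the compounds shown, and "the series" means these compounds.

Among the measured compounds shown here, the three compounds measured so far share one core and differ only in what sits on the oxygen on a saturated carbon. Compound 1 `O=C(CN1CCCC1)OC1CC2(N3CCCCC3)CC(c3ccccc3)C1C(c1ccccc1)C2` carries a ((pyrrolidin-1-yl)methyl)carbonyl there and gives 16400 nM in an ADME assay on L6 cells (Rattus norvegicus) for cytotoxicity, with a stated time of 72 h; a lower number here means a stronger inhibitor, a higher number a weaker inhibitor. Compound 2 `O=C(/C=C/c1ccccc1)OC1CC2(N3CCCCC3)CC(c3ccccc3)C1C(c1ccccc1)C2` carries a (2-phenylethenyl)carbonyl and gives 10500 nM in this assay. Compound 3 `OC1CC2(N3CCCCC3)CC(c3ccccc3)C1C(c1ccccc1)C2` carries only a hydrogen and gives 37300 nM in this assay. Compound 2 has the lowest of the three numbers, but the step of a 1.6-fold lower number from compound 1 to compound 2 (0.19 log units; within the scatter) is within the scatter, so the two cannot be ranked; only its gap to compound 3 a 3.6-fold higher number from compound 2 to compound 3 (0.55 log units; beyond the scatter) is a clear, modest one, as is that from compound 1 a 2.3-fold higher number from compound 1 to compound 3 (0.36 log units; beyond the scatter).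

Compound 4 `CCN(CC)CC(=O)OC1CC2(N3CCCCC3)CC(c3ccccc3)C1C(c1ccccc1)C2` is reached from compound 2 by the change ((diethylamino)methyl in place of 2-phenylethenyl on a carbonyl carbon). For the measured compounds named here, the one measured step that bears on it is the reverse of the swap from compound 1 to compound 2 a 1.6-fold lower number from compound 1 to compound 2 (0.19 log units; within the scatter): an aminomethyl group giving way to 2-phenylethenyl moved the number only within the scatter. Going back from 2-phenylethenyl to a different aminomethyl group, the (diethylamino)methyl, is therefore expected to give at most a small rise in this assay, likely not beyond the scatter, with compound 1 as the nearest comparison. Compound 4 is thus estimated at 15000 nM, between 7000 nM and 32000 nM, a step of a 1.4-fold higher number from compound 2 to compound 4 (0.15 log units; within the scatter) being expected.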

Compound 4, half-maximal inhibitory concentration: 23900 nM
The estimate for compound 4 lay 1.6-fold (0.20 log units) below the measured number; the measured number falls inside the stated range.
By their numbers in this assay, from the lowest: compounds 2, 1, 4 and 3 (each within the scatter of the next, the first and the last beyond it).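

In this assay, the change on this carbonyl carbon now gives a readable difference: a 2.3-fold higher number from compound 2 to compound 4 (0.36 log units; beyond the scatter) is modest but beyond the scatter, whereas the pyrrolidine-bearing group of compound 1 could not be separated from 2-phenylethenyl. The two amine-bearing groups themselves cannot be told apart, with a 1.5-fold higher number from compound 1 to compound 4 (0.16 log units; within the scatter) inside the scatter, so the data do not resolve any effect of exchanging pyrrolidin-1-yl for diethylamino at this place. Also new is that an ester on this oxygen does not always stand clear of plain hydrogen: a 1.6-fold lower number from compound 3 to compound 4 (0.19 log units; within the scatter) lies within the scatter, although compound 1 and compound 2 each stood clear of compound 3.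

From the compounds shown here alone, it remains open whether an acetyl group, a carboxylic acid at the end of the acyl chain, or a longer chain between the carbonyl and the amine would group with compound 4 or with compound 2. Nothing shown here offers an explanation for any of these steps.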